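The source may hold more compounds than are shown below. What is called first, only, known or untested is meant among the compounds shown, and "the series" means these compounds.

Compound 1, `O=S(=O)(Nc1ccc(-c2nc3ccccc3o2)cc1)c1ccccc1Cl`, in an assay on cells for inhibition of HSP60/HSP10 (Homo sapiens), with a stated time of 60 min; a higher number here means a weaker inhibitor, a lower number a stronger inhibitor: > 100000 nM
Compound 2, `O=S(=O)(Nc1ccc(-c2nc3ccccc3o2)cc1)c1ccc(F)cc1`, in this assay: 73000 nM

Two compounds share a core and differ only in the ring on the sulfonyl sulfur. Compound 1 gives no number in this assay, only the limit > 100000 nM. Going by the values given here, compound 2 gives 73000 nM, the single real number among the two values. Among the compounds with values here, the one measured step, an at least 1.3-fold lower number from compound 1 to compound 2 (0.13 log units; that floor lies within the scatter), is a floor that sits within the scatter, and it rests on (the limit of > 100000 nM in this assay, at which 1 of the 2 values shown sits).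

Compound 3, `O=S(=O)(Nc1ccc(-c2nc3cc(NS(=O)(=O)c4ccc(F)cc4)ccc3o2)cc1)c1ccc(F)cc1`, is built from compound 2 by a change at a different place: ((4-fluorophenyl)sulfonyl)amino in place of hydrogen on an aromatic carbon. Within the data shown here, no measured step touches this position, so the measured step from compound 1 to compound 2 gives no direct guide to what the added ((4-fluorophenyl)sulfonyl)amino group will do. The expectation for compound 3 therefore stays near the starting point, with the estimated step of a 1.6-fold lower number from compound 2 to compound 3 (0.21 log units; within the scatter) carrying wide uncertainty. Compound 3 is expected to give about 45000 nM in this assay, within a range from 8000 nM to 200000 nM.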

Compound 3, half-maximal inhibitory concentration: 67000 nM
Estimate against measurement, compound 3: 1.5-fold (0.17 log units) below; measured number inside the range.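

Putting ((4-fluorophenyl)sulfonyl)amino in place of hydrogen on this aromatic carbon, part of the fused system of two rings, gives a 1.1-fold lower number from compound 2 to compound 3 (0.04 log units; within the scatter), so compound 2 and compound 3 cannot be told apart in this assay. Compound 1 and compound 2 both carry hydrogen at this place, so only compound 3 shows that a group of 11 heavy atoms, with its own six-membered aromatic ring, can stand here and leave the number within the usual scatter of the value for compound 2. The change brings no gain that can be read, however, and this small set stays close to the upper limit of what the assay reports: the limit of > 100000 nM in this assay, at which 1 of the 3 values shown sits.

As far as these compounds go, whether a much smaller group on the same carbon, such as an amine or a carboxylic acid, would move the number remains open. So does the question of whether a methoxy group or a pyridine ring in place of the 4-fluorophenyl ring of the new group would give a step larger than the scatter.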